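The source may report more compounds than this note shows. Statements on the series, on what has been measured and on what is new or still open speak of the compounds shown alone.

The measured compounds:

Compound 1, `O=S(=O)(c1ccc(F)cc1)n1c(-c2cn(-c3ccccc3)nc2-c2ccc(F)cc2)nc2ccccc21`, gives 2370 nM
Compound 2, `O=S(=O)(c1ccc(Cl)cc1)n1c(-c2cn(-c3ccccc3)nc2-c2ccc(F)cc2)nc2ccccc21`, gives 3170 nM
Compound 3, `O=S(=O)(c1ccc(F)cc1)n1c(-c2cn(-c3ccccc3)nc2-c2ccc(C(F)(F)F)cc2)nc2ccccc21`, gives 1740 nM

All three were tested in a functional assay on A549 cells (Homo sapiens) for antiproliferative activity, read by MTT assay, with a stated time of 24 h; a lower number here means a stronger inhibitor, a higher number a weaker inhibitor. Compound 1 and compound 2 share one core and differ in a single change, (chloro in place of fluoro on an aromatic carbon). That change gave a 1.3-fold higher number from compound 1 to compound 2 (0.13 log units; within the scatter), so the two values tell the same story. Compound 3 stands on a different core from compound 1, and the difference between the two cores is trifluoromethyl in place of fluoro on an aromatic carbon; the step here was a 1.4-fold lower number from compound 1 to compound 3 (0.13 log units; within the scatter). Compound 3 has the lowest number of the three, but since its distances to compound 1 and compound 2 both lie within the scatter, no one of them can be called the stronger inhibitor.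

Compound 4, `O=S(=O)(c1ccc(Cl)cc1)n1c(-c2cn(-c3ccccc3)nc2-c2ccc(C(F)(F)F)cc2)nc2ccccc21`, has not yet been measured in this assay. It differs from compound 3 by chloro in place of fluoro on an aromatic carbon. The surroundings of the changed position read the same as for the change from compound 1 to compound 2, so this is the same change, now seen for the second time among these compounds. The earlier step was small, a 1.3-fold higher number from compound 1 to compound 2 (0.13 log units; within the scatter), and there is no reason from these data to expect a different outcome on the other core, so a step of about a 1.3-fold higher number from compound 3 to compound 4 (0.12 log units; within the scatter) is expected. Compound 4 is therefore estimated at 2300 nM in this assay, with a likely range from 1200 nM to 4500 nM.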

Compound 4, half-maximal inhibitory concentration: 2560 nM
Compound 4: the middle estimate sits 1.1-fold (0.05 log units) below what was measured, and the stated range covers the measured number.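

In this assay, among the compounds shown here, chloro in place of fluoro gives a 1.5-fold higher number from compound 3 to compound 4 (0.17 log units; within the scatter), and this step agrees with the one seen earlier on the other core: the same change on two cores in this assay, a 1.3-fold higher number (0.13 log units; within the scatter) from compound 1 to compound 2 and a 1.5-fold higher number (0.17 log units; within the scatter) from compound 3 to compound 4, 1.1-fold (0.04 log units) apart, within the scatter of two such steps Trifluoromethyl in place of fluoro gives a 1.2-fold lower number from compound 2 to compound 4 (0.09 log units; within the scatter), and this step also agrees with its earlier counterpart: the same change on two cores in this assay, a 1.4-fold lower number (0.13 log units; within the scatter) from compound 1 to compound 3 and a 1.2-fold lower number (0.09 log units; within the scatter) from compound 2 to compound 4, 1.1-fold (0.04 log units) apart, within the scatter of two such steps Each change therefore behaves alike on the two cores tested, but since every step lies within the scatter, this shows only that neither change produced a clear shift in the number on these cores, not that either has a real effect, and two cores cannot show how the changes would behave on a third.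

The compounds shown leave open whether a group of a different kind at these places, such as an amine, a carboxylic acid or a methoxy group, would give a step beyond the scatter. They also leave open whether a step of that size would carry from one core to another as faithfully as these small ones do, since a match between steps this small is a weak test of that.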